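This account rests on a few compounds, and the source may have more. Where it says the series, first, only, none or still open, it means among the compounds named here.

Measured compounds in a functional assay on A549 cells (Homo sapiens) for cytotoxicity, read by MTT assay, with a stated time of 72 h; a higher number here means that more compound is needed for the effect, a lower number that less compound is needed:
- compound 1 `O=c1cc(Nc2ccccc2)cc(-c2ccccc2)o1`: 0.12 uM
- compound 2 `Cc1ccc(Nc2cc(-c3ccccc3)oc(=O)c2)cc1`: 0.067 uM

Within the data shown here, only two compounds have been measured so far. Compound 1 has the higher of the two numbers; its nearest neighbour is compound 2, and the step of a 1.8-fold lower number from compound 1 to compound 2 (0.25 log units; within the scatter) lies within the scatter, so the two values cannot be told apart. Among the measured compounds shown here, that step, a methyl in place of hydrogen on an aromatic carbon, is the only measured change in the set.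

Compound 3 `COc1ccccc1Nc1cc(-c2ccccc2)oc(=O)c1` has not yet been measured. It differs from compound 1 by methoxy in place of hydrogen on an aromatic carbon, on an aromatic carbon of the six-membered carbon-only ring, ortho to a large group. For the measured compounds named here, no measured step covers a methoxy at this place; the single measured step, from compound 1 to compound 2, concerned a different group and was within the scatter. Nothing in the data therefore points to a shift beyond the scatter for compound 3 in this assay, and a step of about a 1.1-fold higher number from compound 1 to compound 3 (0.03 log units; within the scatter) is expected. For compound 3 the estimate in this assay is 0.13 uM, with a range from 0.04 uM to 0.4 uM.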

Compound 3, concentration for half-maximal effect: 0.44 uM
The estimate for compound 3 lay 3.4-fold (0.53 log units) below the measured number; the whole stated range lies below it.
By their numbers in this assay, from the lowest: compounds 2 and 1 (each within the scatter of the next); then compound 3.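

In this assay, the aromatic carbon ortho to a large group on the six-membered aromatic ring of carbon only proves sensitive to substitution: methoxy in place of hydrogen there gives a 3.7-fold higher number from compound 1 to compound 3 (0.56 log units; beyond the scatter) as a modest step, the only one in the set that lies beyond the scatter. The earlier pair offered only a methyl in place of hydrogen on an aromatic carbon, with a 1.8-fold lower number from compound 1 to compound 2 (0.25 log units; within the scatter) as its step, so until now no single change could be told apart from the scatter. No measured information bears on why the methoxy at this place raises the number, so the step stands as an observation without an explanation.

Going by these compounds, it remains open whether the rise belongs to the methoxy itself or to its place, a question that would turn on a methyl at this same carbon and on a methoxy elsewhere on that ring. On these data alone, it also remains open whether a fluorine, a hydroxy group or an amine at this carbon would shift the number in the same direction, or whether it would stay within the scatter of compound 1.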